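The source may hold more compounds than are shown below. What is called first, only, known or untested is meant among the compounds shown, and "the series" means these compounds.

Compound 1 `CN(C)CCn1cnnc1-c1cc(Oc2ccc(NC(=O)N/N=C/c3c[nH]c4ccccc34)cc2F)ccn1`: 790 nM
Compound 2 `COc1ccc(/C=N/NC(=O)Nc2ccc(Oc3ccnc(-c4nncn4CCN(C)C)c3)c(F)c2)c(OC)c1`: 1680 nM
Compound 3 `CN(C)CCn1cnnc1-c1cc(Oc2ccc(NC(=O)N/N=C/c3c(O)ccc4ccccc34)cc2F)ccn1`: 2020 nM

In a functional assay on MKN-45 cells (Homo sapiens) for cytotoxicity, read by MTT assay, with a stated time of 72 h (a higher number here means a weaker inhibitor, a lower number a stronger inhibitor), compound 1 gives 790 nM, the lowest of the three numbers. Both measured replacements at the carbon with a double bond to nitrogen raised the number: a 2.1-fold higher number from compound 1 to compound 2 (0.33 log units; beyond the scatter) and a 2.6-fold higher number from compound 1 to compound 3 (0.41 log units; beyond the scatter). Between the two replacement groups themselves the difference stays small, a 1.2-fold higher number from compound 2 to compound 3 (0.08 log units; within the scatter). Compound 4 `CN(C)CCn1cnnc1-c1cc(Oc2ccc(NC(=O)N/N=C/c3ccc(O)cc3)cc2F)ccn1` alters the same position once more: 4-hydroxyphenyl in place of 1H-indol-3-yl on a carbon with a double bond to nitrogen. Because a 2.1-fold higher number from compound 1 to compound 2 (0.33 log units; beyond the scatter) and a 2.6-fold higher number from compound 1 to compound 3 (0.41 log units; beyond the scatter) both point upward by modest amounts, a rise of similar size is expected for compound 4, a 2.0-fold higher number from compound 1 to compound 4 (0.31 log units; beyond the scatter). Compound 4 is accordingly estimated at 1600 nM, with a range from 700 nM to 3600 nM.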

Compound 4, half-maximal inhibitory concentration: 820 nM
Beside the measured number, compound 4's estimate is 2.0-fold (0.29 log units) above it; low and high end bracket the measured number.
By their numbers in this assay, from the lowest: compounds 1 and 4 (each within the scatter of the next); then compounds 2 and 3 (each within the scatter of the next).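

In this assay, among these compounds, a group with only one six-membered aromatic ring matches 1H-indol-3-yl at this carbon, with a 1.0-fold higher number from compound 1 to compound 4 (0.02 log units; within the scatter). The same 4-hydroxyphenyl group also stands apart from the other two replacements, with a 2.5-fold lower number from compound 3 to compound 4 (0.39 log units; beyond the scatter) and a 2.0-fold lower number from compound 2 to compound 4 (0.31 log units; beyond the scatter), so a change at this position need not raise the number, and compound 3 shows that carrying a hydroxyl does not by itself keep it low. No available measurement accounts for these differences. As far as these compounds go, it remains open whether the hydroxyl of compound 4 matters at all, and whether an amine or a carboxylic acid in its place would keep the number.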